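Methyl in Place of Chloro: Three Limits and an Expectation

This account rests on a few compounds, and the source may have more. Where it says the series, first, only, none or still open, it means among the compounds named here.

Compound 1 `COc1ccc(Cc2cc(-c3ccc(Cl)cc3)nn(CC(=O)Nc3ccc(Br)cc3)c2=O)cc1` reaches only the limit of an assay on HL-60 cells for agonist activity at N-formyl peptide receptor 3 (Homo sapiens), read by calcium flux (a lower number here means that less compound is needed, a higher number that more compound is needed for the effect), namely > 50000 nM.
Compound 2 `COc1cccc(Cc2cc(-c3ccc(Cl)cc3)nn(CC(=O)Nc3ccc(F)cc3)c2=O)c1` likewise reaches only the limit of this assay, > 50000 nM.
Compound 3 `COc1ccc(Cc2cc(-c3ccc(C)cc3)nn(CC(=O)Nc3ccc(Br)cc3)c2=O)cc1` also reaches only the limit of this assay, > 50000 nM.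

Compound 4 `COc1cccc(Cc2cc(-c3ccc(C)cc3)nn(CC(=O)Nc3ccc(F)cc3)c2=O)c1` has not yet been measured in this assay. It differs from compound 2 by methyl in place of chloro on an aromatic carbon. The same kind of change separates compound 1 from compound 3, where it reads (methyl in place of chloro on an aromatic carbon); the two place lines agree word for word. The measured step for that change, a step that the two limits leave unreadable from compound 1 to compound 3, cannot be read because the limit of > 50000 nM in this assay, at which 3 of the 3 values shown sit, holds both ends of it. For the measured compounds named here, how the core of compound 2 differs from the core of compound 1 is not broken down here; the two values show only that both compounds sit at the limit.

Because the limit of > 50000 nM in this assay, at which 3 of the 3 values shown sit, is where all three measured compounds sit, there is no graded value anywhere in the set on which a size for the change could be read. The account for compound 4 therefore rests on compound 2 giving > 50000 nM and on the unreadable step that the two limits leave unreadable from compound 1 to compound 3. The step from compound 2 to compound 4 is expected to be a step that the limit leaves unreadable from compound 2 to compound 4, in the sense that no movement away from the limit is anticipated. Compound 4 is estimated at 100000 nM, expected to fall between 40000 nM and 500000 nM, most likely again reported only as a limit.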

Compound 4, half-maximal effective concentration: > 50000 nM
Compound 4 gave a limit, no number; the forecaster's own chance of this, stated with the estimate: 90%; the middle value does not contradict the limit.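

In this assay compound 4 gives > 50000 nM as a limit and not a number. No step can be read from compound 2 to compound 4, where 4-chlorophenyl gives way to 4-methylphenyl, and the whole set stays unreadable: the limit of > 50000 nM in this assay, at which 4 of the 4 values shown sit. The compounds shown leave open whether methyl in place of chloro has any effect of measurable size in this assay on a compound that gives a graded value.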